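The source may report more compounds than this note shows. Statements on the series, on what has been measured and on what is new or still open speak of the compounds shown alone.

Working notes on the series. The parent, compound 1 `COc1ccccc1/C=c1/[nH]c(=O)/c(=C\c2ccccc2OC)[nH]c1=O`, gives "not active" (no number reported) in a functional assay on MCF7 cells (Homo sapiens) for cytotoxicity, read by CCK-8 assay, with a stated time of 72 h; a higher number here means a weaker inhibitor, a lower number a stronger inhibitor. Compound 2 `C=CCn1c(=O)/c(=C\c2cccc(F)c2)[nH]c(=O)/c1=C\c1ccccc1OC` gives 13700 nM in this assay, and compound 3 `C=CCn1c(=O)/c(=C\c2cc(F)ccc2C)[nH]c(=O)/c1=C\c1ccccc1OC` gives 3100 nM. For the measured compounds named here, compound 3 thus holds the lowest number of the two reported, with compound 2 the nearest at a higher number; the single step seen so far, a 4.4-fold lower number from compound 2 to compound 3 (0.65 log units; beyond the scatter), is a modest one and the only guide available.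

The next compound, compound 4 `C=CCn1c(=O)/c(=C\c2cccc(Br)c2)[nH]c(=O)/c1=C\c1ccccc1OC`, differs from compound 3 as follows: 3-bromophenyl in place of 5-fluoro-2-methylphenyl on a double-bonded chain carbon bound to an aromatic carbon. This removes the methyl whose addition gave the step from compound 2 to compound 3, and swaps the halogen on the same phenyl from fluorine to bromine. Going by the values given here, no measured pair covers a fluorine-to-bromine exchange, so only the methyl loss can be weighed, and it points back toward the number of compound 2. Compound 4 is therefore expected near 10000 nM, between 3000 nM and 35000 nM, the estimated step being a 3.2-fold higher number from compound 3 to compound 4 (0.51 log units; beyond the scatter), an increase beyond the scatter.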

Compound 4, half-maximal inhibitory concentration: 5400 nM
Compound 4: the middle estimate sits 1.9-fold (0.27 log units) above what was measured, within the range that was stated.
By their numbers in this assay, from the lowest: compounds 3 and 4 (each within the scatter of the next); then compound 2.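

Bromo in place of fluoro on an aromatic carbon gives a 2.5-fold lower number from compound 2 to compound 4 (0.40 log units; beyond the scatter) in this assay, so the halogen on this phenyl changes the number without any help from a methyl. For the compounds shown here, exchanging 5-fluoro-2-methylphenyl for 3-bromophenyl on the double-bonded chain carbon gives a 1.7-fold higher number from compound 3 to compound 4 (0.24 log units; within the scatter), so this read-out does not separate the two groups, and the methyl is not the only route to a number in this range. No measured evidence accounts for either step.

Still open, as far as these compounds go, is whether chloro or iodo in place of bromo would extend the step seen on going from fluoro to bromo, or whether a morpholine or a carboxylic acid would be tolerated on this phenyl. Also open, from the compounds shown here alone, is whether a methyl added to the 3-bromophenyl of compound 4 would give a further step of its own.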